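The compounds below may be only part of what the source reports. "The series", "measured", "known", "first", "only" and "open" are said of these compounds alone.

Compound 1 `CC(C(=O)NCc1ccc(C(F)(F)F)cc1N1CCN(c2ccccc2)CC1)c1ccc(NS(C)(=O)=O)c(F)c1`: 2 nM
Compound 2 `CCCCCCSc1cc(C(F)(F)F)ccc1CNC(=O)C(C)c1ccc(NS(C)(=O)=O)c(F)c1`: 1.8 nM

For the measured compounds named here, in an assay on CHO cells for antagonist activity at transient receptor potential cation channel subfamily V member 1 (Homo sapiens), read by FLIPR (a lower number here means a stronger inhibitor, a higher number a weaker inhibitor), compound 2 shows the lower of the two numbers, yet the single measured step, a 1.1-fold lower number from compound 1 to compound 2 (0.05 log units; within the scatter), lies within the scatter, so the two compounds cannot be told apart. Compound 3 `CC(C(=O)NCc1ccc(C(F)(F)F)cc1C1CCCCC1)c1ccc(NS(C)(=O)=O)c(F)c1` differs from compound 2 by cyclohexyl in place of hexylsulfanyl on an aromatic carbon. Going by the values given here, only that one step bears on this position, and it showed that exchanging one large group for another there left the number unchanged. A similar outcome is expected here, a 1.7-fold higher number from compound 2 to compound 3 (0.22 log units; within the scatter). Compound 3 is therefore estimated at 3 nM, with a range from 1 nM to 10 nM.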

Compound 3, inhibition constant: 0.6 nM
Estimate against measurement, compound 3: 5.0-fold (0.70 log units) above, outside the stated range (below it).
By their numbers in this assay, from the lowest: compound 3; then compounds 2 and 1 (each within the scatter of the next).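

In this assay the choice of large group on this aromatic carbon does matter: cyclohexyl gives a 3.0-fold lower number from compound 2 to compound 3 (0.48 log units; beyond the scatter) in place of hexylsulfanyl and a 3.3-fold lower number from compound 1 to compound 3 (0.52 log units; beyond the scatter) in place of 4-phenylpiperazin-1-yl. Both steps are modest, yet they separate compound 3 from two compounds that could not be told apart. Nothing measured here accounts for this difference.

The compounds shown leave open whether cyclohexyl is special among rings, since cyclopentyl and phenyl do not appear among them. On these data alone, how an amine or a carboxylic acid on this carbon would compare also remains unknown.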